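Chloro for Methoxy on the Aryl Ring of Compound 1

The source may hold more compounds than are shown below. What is called first, only, known or untested is meant among the compounds shown, and "the series" means these compounds.

Compound 1 `C=CC(=O)N1C(=O)CC(c2ccc(OC)cc2)Sc2ccccc21`: 92100 nM
Compound 2 `C=CC(=O)N1C(=O)CC(c2ccc(-c3ccccc3)cc2)Sc2ccccc21`: 118000 nM
Compound 3 `C=CC(=O)N1C(=O)CC(C)Sc2ccccc21`: 199000 nM

Of the compounds shown here, three sharing one core have been tested in a functional assay on HL-60 cells (Homo sapiens) for cytotoxicity, read by CCK-8 assay, with a stated time of 24 h; a higher number here means a weaker inhibitor, a lower number a stronger inhibitor. Compound 1 gives the lowest of the three numbers. Compound 2 carries phenyl in place of methoxy on an aromatic carbon, and the step of a 1.3-fold higher number from compound 1 to compound 2 (0.11 log units; within the scatter). Compound 3 carries methyl in place of 4-methoxyphenyl on a saturated ring carbon, and the step of a 2.2-fold higher number from compound 1 to compound 3 (0.33 log units; beyond the scatter). Within this small set, a change at the aromatic carbon therefore left the number essentially where it was, while removing the whole aryl group moved it modestly.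

Compound 4 `C=CC(=O)N1C(=O)CC(c2ccc(Cl)cc2)Sc2ccccc21` is the next compound. Compared with compound 1, the change is chloro in place of methoxy on an aromatic carbon.

Within the data shown here, the step that bears on this change is the one from compound 1 to compound 2. It alters the same aromatic carbon and stayed within the scatter. The step from compound 1 to compound 3 concerns a different place and is less informative here. On this basis the step from compound 1 to compound 4 is expected to be a 1.0-fold higher number from compound 1 to compound 4 (0.01 log units; within the scatter), not beyond the scatter in either direction. Compound 4 is accordingly estimated at 95000 nM, with a range from 45000 nM to 200000 nM.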

Compound 4, half-maximal inhibitory concentration: 95700 nM
The estimate for compound 4 lay 1.0-fold (0.00 log units) below the measured number; the range from low to high includes it.
By their numbers in this assay, from the lowest: compounds 1, 4, 2 and 3 (each within the scatter of the next, the first and the last beyond it).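

In this assay, the aromatic carbon para to a large group has now carried methoxy, phenyl and chloro without the number separating them: a 1.0-fold higher number from compound 1 to compound 4 (0.02 log units; within the scatter) and a 1.2-fold lower number from compound 2 to compound 4 (0.09 log units; within the scatter) both stay within the scatter. The single chlorine atom thus joins a two-atom methoxy and a whole phenyl ring in giving readings that cannot be told apart here, so the first indication from compound 2 now rests on a second, much smaller group. The saturated ring carbon also gains a second comparison, as a 2.1-fold lower number from compound 3 to compound 4 (0.32 log units; beyond the scatter) is again modest and beyond the scatter, so the step seen with 4-methoxyphenyl against methyl recurs with 4-chlorophenyl, and no information at hand accounts for either the flat aromatic position or this step.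

It remains open whether an amine, a carboxylic acid or a hydroxyl group on the same aromatic carbon would also stay within the scatter, since all three groups shown there lack a net charge and a hydrogen-bond donor. At the saturated ring carbon, a longer chain such as hexyl or a cyclohexyl ring could show whether the number follows an aromatic ring specifically or any group larger than methyl.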